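Replacing a ring hydroxy on compound 3 with hydrogen

A few compounds are considered here, and "the series" means these few. Any claim that something is new, unique, unknown or untested is made for them only; others in the source may bear on it.

In a functional assay on HeLa cells (Homo sapiens) for cytotoxicity, read by MTT assay, with a stated time of 24 h (on this read-out higher numbers stand for weaker inhibition and lower numbers for stronger inhibition), compound 3 `C/C=C(\C)C(=O)C[C@@H]1[C@@]2(C)[C@@H](O)CCC(C)(C)[C@]2(O)CC[C@@]1(C)O` gives > 10000 nM, which is a limit of the assay. Compound 1 `C[C@@H]1O[C@@]1(C)C(=O)C[C@H]1[C@](C)(O)CC[C@@]2(O)C(C)(C)CCC[C@]12C` gives > 10000 nM, also a limit. Compound 2 `C[C@H]1O[C@]1(C)C(=O)C[C@H]1[C@](C)(O)CC[C@@]2(O)C(C)(C)CCC[C@]12C` gives > 10000 nM, again a limit. Compound 3 therefore has no numerical standing in the series, only a shared position: the limit of > 10000 nM in this assay, at which 3 of the 3 values shown sit.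

Compound 4 `C/C=C(\C)C(=O)C[C@H]1[C@](C)(O)CC[C@@]2(O)C(C)(C)CCC[C@]12C` carries hydrogen in place of hydroxy on a saturated ring carbon. Within the data shown here, the only measured step is a step that the two limits leave unreadable from compound 1 to compound 2. Among the measured compounds shown here, it rests on (the fact that compounds 1 and 2 differ only in the configuration as drawn), and no measured step removes a hydroxy, so it offers no size to carry over.

With compound 3 recorded only as the limit > 10000 nM, nothing supports an expected gain in this assay, and no shift beyond the scatter is expected in either direction. The estimated step is a step that the limit leaves unreadable from compound 3 to compound 4. For compound 4 the estimated value is 20000 nM, with an expected range of 8000 nM to 60000 nM, and a report of only a limit is the likeliest outcome.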

Compound 4, half-maximal inhibitory concentration: > 10000 nM
Compound 4: only a limit was reported (the forecaster's own chance of this, stated with the estimate: 85%); the middle value is on the limit's open side.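

In this assay compound 4 gives > 10000 nM, a limit of the assay. Among these compounds, no step to compound 1, compound 2 or compound 3 can be read, as these also stand as limits. The compounds shown leave open how the hydroxy or 2,3-dimethyloxiran-2-yl changes affect cytotoxicity: the limit of > 10000 nM in this assay, at which 4 of the 4 values shown sit.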